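A Cyclohexyl Group on an Aromatic Nitrogen

A few compounds are considered here, and "the series" means these few. Any claim that something is new, unique, unknown or untested is made for them only; others in the source may bear on it.

Compound 1 `O=c1[nH]c(Oc2cccnc2)nc2cnccc12` and compound 2 `O=c1[nH]c(Oc2cn[nH]c2)nc2cnccc12` share a core and differ only in the aromatic ring on an oxygen. In a physicochemical assay for lipophilicity, at pH 7.4 (on this read-out higher numbers stand for higher lipophilicity and lower numbers for lower lipophilicity), compound 1 gives -0.2, while compound 2 gives -0.6, the lower of the two numbers. Within the data shown here, the one measured step, a number 0.40 log units lower from compound 1 to compound 2 (beyond the scatter), is modest and comes from 1H-pyrazol-4-yl in place of pyridin-3-yl.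

Compound 3 `O=c1[nH]c(Oc2cnn(C3CCCCC3)c2)nc2cnccc12` has not been measured. It carries cyclohexyl in place of hydrogen on an aromatic nitrogen. The measured step swaps one aromatic ring for another, whereas this change adds a ring of carbon only, so it offers only a rough sense of scale. A rise far larger than a number 0.40 log units lower from compound 1 to compound 2 (beyond the scatter) is therefore expected. In this assay the expected change is a number 2.00 log units higher from compound 2 to compound 3 (beyond the scatter). For compound 3 the estimated value is 1.4, with an expected range from 0.7 to 2.1.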

Compound 3, distribution coefficient: 2.2
For compound 3 the middle estimate is 0.80 log units below the measured one; the measured number lies above the stated range.
By their numbers in this assay, from the lowest: compound 2; then compound 1; then compound 3.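

In this assay the hydrogen on the aromatic nitrogen proves to be a place where one change can move the number a long way: cyclohexyl there gives a number 2.80 log units higher from compound 2 to compound 3 (beyond the scatter) and so outruns the modest a number 0.40 log units lower from compound 1 to compound 2 (beyond the scatter) by a wide margin. Among these compounds, the earlier compounds showed only one aromatic ring exchanged for another on the oxygen, whereas this step alters the ring nitrogen itself and brings in a six-membered non-aromatic ring of carbon only, with no hydrogen-bond donors or acceptors. Nothing available explains why the step is this large.

With a single group on this nitrogen, no trend with size can be drawn. Open questions are how far methyl or a longer chain would move the number, and what an amine or a carboxylic acid on the cyclohexyl ring would do.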